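Methyl in place of hydrogen on the phenyl of compound 2

The source may report more compounds than this note shows. Statements on the series, on what has been measured and on what is new or still open speak of the compounds shown alone.

Compound 2 `Cc1nc(-c2cccnc2)sc1-c1nnc(-c2ccccc2)o1` has been tested in an ADME assay on HCT-116 cells (Homo sapiens) for cytotoxicity, read by MTT assay; a higher number here means that more compound is tolerated, a lower number that less compound is tolerated. In this assay compound 2 gives only a limit, > 100 ug/mL, and not a number. Compound 1 `Cc1nc(-c2cccnc2)sc1-c1nnc(-c2ccc([N+](=O)[O-])cc2)o1` likewise reaches only a limit in this assay, > 100 ug/mL. The step from compound 1 to compound 2, hydrogen in place of nitro on an aromatic carbon, is a step that the two limits leave unreadable from compound 1 to compound 2; both values sit at the limit of > 100 ug/mL in this assay, at which 2 of the 2 values shown sit, so no size can be read from it.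

Compound 3 `Cc1ccccc1-c1nnc(-c2sc(-c3cccnc3)nc2C)o1` differs from compound 2 by methyl in place of hydrogen on an aromatic carbon, which cut one bond further out reads phenyl to 2-methylphenyl. Within the data shown here, no measured step bears on a methyl, and the one step that exists is unreadable, so nothing argues for a change beyond the scatter. Compound 3 is therefore expected to give about 150 ug/mL, within 60 ug/mL to 400 ug/mL, most likely again only a limit, a step from compound 2 estimated as a step that the limit leaves unreadable from compound 2 to compound 3.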

Compound 3, half-maximal cytotoxic concentration: > 100 ug/mL
Compound 3 was reported as a limit; the forecaster's own chance of this, stated with the estimate: 80%; the middle value is on the limit's open side.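

Compound 3, like compound 2, gives only a limit in this assay, so no step between them can be read: the limit of > 100 ug/mL in this assay, at which 3 of the 3 values shown sit.

The compounds shown leave open whether nitro or methyl on the phenyl makes any difference to how much compound is tolerated past that limit.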